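A 4-methoxyphenyl swap on a weak growth inhibitor

The source may report more compounds than this note shows. Statements on the series, on what has been measured and on what is new or still open speak of the compounds shown alone.

In a functional assay on DU-145 cells (Homo sapiens) for inhibition, read by trypan blue exclusion, with a stated time of 96 h (on this read-out lower numbers stand for stronger inhibition of growth and higher numbers for weaker inhibition of growth), compound 1 (`O=C(/C(=C\c1ccc(Cl)cc1Cl)S(=O)(=O)c1ccc(Br)cc1)c1ccc(Cl)cc1`) gives 50000 nM and stands highest of the two numbers measured, while compound 2 (`O=C(/C(=C\c1ccc(O)c([N+](=O)[O-])c1)S(=O)(=O)Cc1ccccc1Cl)c1ccc(Cl)cc1`) gives 10000 nM and stands lower, beyond the scatter. Compound 3 (`COc1ccc(/C=C(\C(=O)c2ccc(Cl)cc2)S(=O)(=O)c2ccc(Br)cc2)cc1`) carries 4-methoxyphenyl in place of 2,4-dichlorophenyl on a double-bonded chain carbon bound to a double-bonded chain carbon. Going by the values given here, no measured pair isolates this change. Among the compounds with values here, the only guide is compound 2, which lacks the 2,4-dichlorophenyl group and reads 10000 nM in this assay on a different substitution pattern. The expected 3.3-fold lower number from compound 1 to compound 3 (0.52 log units; beyond the scatter) is a moderate one toward stronger inhibition. In this assay the estimate for compound 3 is 15000 nM (expected range 3000 nM to 50000 nM).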

Compound 3, concentration for 50% growth inhibition: 10000 nM
Estimate against measurement, compound 3: 1.5-fold (0.18 log units) above, within the range that was stated.
By their numbers in this assay, from the lowest: compounds 2 and 3 (each within the scatter of the next); then compound 1.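

Going by these compounds alone, compound 1 and compound 3 form the first pair that isolates a change at this position, and they show that the group on this double-bonded chain carbon affects growth inhibition: 4-methoxyphenyl in place of 2,4-dichlorophenyl gives a 5.0-fold lower number from compound 1 to compound 3 (0.70 log units; beyond the scatter) in the direction of stronger inhibition. This single swap cannot separate the loss of the two chlorines from the gain of the methoxy group. Nothing available accounts for the shift.

From the compounds shown here alone, it remains open how a 4-aminophenyl or 4-carboxyphenyl group would read in the same place, and whether the same swap would give a similar step with the other groups of the core changed.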